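This account rests on a few compounds, and the source may have more. Where it says the series, first, only, none or still open, it means among the compounds named here.

Measured so far:
- compound 1 `COc1cc(OC)cc(-c2cccc(NC(=O)CCc3cccc4c3B(O)OC4)c2)c1`: 40 nM
- compound 2 `COc1cccc(-c2cccc(NC(=O)CCc3cccc4c3COB4O)c2)c1`: 76000 nM

These two compounds have been tested in a functional assay on MDA-MB-231 cells (Homo sapiens) for antiproliferative activity, read by MTT assay, with a stated time of 72 h; a higher number here means a weaker inhibitor, a lower number a stronger inhibitor. Compound 2 stands at the higher, weaker end of this pair at 76000 nM. Compound 1, at 40 nM, lies far from it, well beyond the usual scatter of repeat measurements.

The next compound is compound 3 `COc1cc(OC)cc(-c2cccc(NC(=O)CCc3cccc4c3COB4O)c2)c1`, which differs from compound 2 in a single place: methoxy in place of hydrogen on an aromatic carbon. In words, a methoxy stands in place of hydrogen on an aromatic carbon, turning 3-methoxyphenyl into 3,5-dimethoxyphenyl.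

For the measured compounds named here, no measured pair shows this change on its own, so any expectation rests on thin evidence. Compound 1 already carries 3,5-dimethoxyphenyl and gives 40 nM, although its core is not the same as that of compound 2 and compound 3. That makes a clear gain in strength plausible, though not a full match with compound 1. The expected change is a 25-fold lower number from compound 2 to compound 3 (1.40 log units; beyond the scatter), a large move towards a lower number and beyond the scatter. For compound 3 the estimated value is 3000 nM, with an expected range from 150 nM to 40000 nM.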

Compound 3, half-maximal inhibitory concentration: 93000 nM
Beside the measured number, compound 3's estimate is 31-fold (1.49 log units) below it; measured number outside the range, above it.
By their numbers in this assay, from the lowest: compound 1; then compounds 2 and 3 (each within the scatter of the next).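

In this assay, the added methoxy gives a 1.2-fold higher number from compound 2 to compound 3 (0.09 log units; within the scatter) and turns 3-methoxyphenyl into 3,5-dimethoxyphenyl, so on the core shared by these two compounds the two groups cannot be told apart. The 3,5-dimethoxyphenyl group therefore does not bring the low number of compound 1 with it: with this group held constant, the change of core alone gives a 2300-fold higher number from compound 1 to compound 3 (3.37 log units; beyond the scatter) and is a large step. No measurement here explains why the core carries so much weight or why the methoxy has no visible effect on this core.

The compounds shown leave open whether the same methoxy would count on the core of compound 1, since that core appears here only with 3,5-dimethoxyphenyl. They also leave open how a hydroxy group or an amine would read at this aromatic carbon, and whether a longer chain between the core and the amide would change the large gap between the two cores.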